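A few compounds are considered here, and "the series" means these few. Any claim that something is new, unique, unknown or untested is made for them only; others in the source may bear on it.

Compound 1, `COc1ccc2nc(C)cc(OCC(=O)Nc3cc(C)cc(C)c3)c2c1`, gives 20000 nM in a toxicity assay on HepG2 cells (Homo sapiens) for inhibition, read by CellTiter-Glo, with a stated time of 48 h; a higher number here means a weaker inhibitor, a lower number a stronger inhibitor. Compound 3, `COc1ccc2nc(C)cc(OCC(=O)Nc3ccc(F)cc3)c2c1`, gives 63100 nM in this assay. For compound 2, `COc1ccc2nc(C)cc(OCC(=O)NCc3cc(C)cc(C)c3)c2c1`, only a limit is known, > 100000 nM.

Of the two numbers at hand, compound 3 is the higher one: the step of a 3.2-fold higher number from compound 1 to compound 3 (0.50 log units; beyond the scatter) is beyond the scatter, while compound 2 sits at a limit (the limit of > 100000 nM in this assay, at which 1 of the 3 values shown sits), so its distance to compound 3 is only a floor, an at least 1.5-fold lower number from compound 2 to compound 3 (0.19 log units; that floor lies within the scatter).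

Compound 4, `COc1ccc2nc(C)cc(OCC(=O)Nc3cccnc3)c2c1`, differs from compound 3 in one place: pyridin-3-yl in place of 4-fluorophenyl on an amide-type nitrogen. Among the compounds with values here, no measured step makes exactly this exchange. The closest comparison is the swap of one aryl group for another, a 3.2-fold higher number from compound 1 to compound 3 (0.50 log units; beyond the scatter), which moved the number modestly. The step from compound 2 to compound 3 changed more than the ring and lies within the scatter.

From this, the step of a 1.1-fold higher number from compound 3 to compound 4 (0.05 log units; within the scatter) is expected to be small, most likely no larger than the scatter. Compound 4 is therefore estimated at 70000 nM, with a range of 25000 nM to 200000 nM.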

Compound 4, half-maximal inhibitory concentration: > 100000 nM
Compound 4 ended at the assay's limit; the forecaster's own chance of this, stated with the estimate: 30%; at least 1.4-fold (0.15 log units) between middle value and limit.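

In this assay, the exchange of 4-fluorophenyl for pyridin-3-yl on the amide-type nitrogen can be read only as a floor, an at least 1.5-fold higher number from compound 3 to compound 4 (0.19 log units; that floor lies within the scatter), so these data do not separate compound 4 from compound 3. The comparison with the 3,5-dimethylphenyl group is clearer, an at least 5.0-fold higher number from compound 1 to compound 4 (0.69 log units; beyond the scatter), and compound 1 remains the strongest inhibitor of the four in this assay. The step from compound 2 to compound 4 cannot be read, as both values are limits rather than numbers: the limit of > 100000 nM in this assay, at which 2 of the 4 values shown sit.

The compounds shown leave open how far above the limit compound 4 lies, and whether pyridin-2-yl or pyridin-4-yl on this nitrogen would behave like pyridin-3-yl. They also leave open what an unsubstituted phenyl group, or a phenyl group carrying an amine or a carboxylic acid, would give here.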